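The compounds below may be only part of what the source reports. "The series", "measured", "known", "first", "only" and "open" are said of these compounds alone.

Measured so far:
Compound 1, `O=C1CN(C2CCCC2)c2nc(Nc3ccc(N4CCCCC4)cn3)ncc2N1`. In a functional assay on MDA-MB-231 cells (Homo sapiens) for inhibition, read by MTT assay, with a stated time of 48 h (a higher number here means a weaker inhibitor, a lower number a stronger inhibitor), compound 1 gives > 30000 nM, which is a limit of the assay rather than a number.
Compound 2, `CCN1C(=O)CN(C2CCCC2)c2nc(Nc3ccc(N4CCN(C)CC4)cn3)ncc21`. In this assay compound 2 gives 24100 nM.

Going by the values given here, compound 2 therefore holds the only actual number among the two entries, the other entry being (the limit of > 30000 nM in this assay, at which 1 of the 2 values shown sits). Even so, compound 2 is a weak inhibitor on this scale.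

The next compound, compound 3, `CCN1C(=O)CN(C2CCCC2)c2nc(Nc3ccc(N4CCCCC4)cn3)ncc21`, differs from compound 2 in one place: piperidin-1-yl in place of 4-methylpiperazin-1-yl on an aromatic carbon. Among the compounds with values here, no measured step between two numbered compounds covers this change, so its size can only be guessed from what the two entries show. Compound 1, which also carries piperidin-1-yl, gives only > 30000 nM, a limit. On that basis compound 3 is expected to come out somewhat weaker than its parent, with an expected step of a 1.5-fold higher number from compound 2 to compound 3 (0.16 log units; within the scatter), probably at or near the edge of the scatter and with a fair chance that the assay again reports only a limit. The estimate for compound 3 is 35000 nM, with a range from 12000 nM to 100000 nM.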

Compound 3, half-maximal inhibitory concentration: 28200 nM
Beside the measured number, compound 3's estimate is 1.2-fold (0.09 log units) above it; the range from low to high includes it.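

In this assay, the change at this position, on an aromatic carbon two atoms from the ring nitrogen, now has a measured size: a 1.2-fold higher number from compound 2 to compound 3 (0.07 log units; within the scatter). Piperidin-1-yl and 4-methylpiperazin-1-yl, which differ by one hetero atom in the six-membered ring, therefore cannot be told apart in this read-out on the core that carries the ethyl group. On these data alone, the other pair isolates ethyl in place of hydrogen on the amide-type nitrogen in a ring, but it gives only a floor, an at least 1.0-fold lower number from compound 1 to compound 3 (0.02 log units; that floor lies within the scatter), so no effect of the ethyl group can be read from it, and the upper end of this step stays unknown: the limit of > 30000 nM in this assay, at which 1 of the 3 values shown sits.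

The compounds shown leave open whether any group at this position moves the number beyond the scatter, for instance a morpholine, a piperazine that keeps its amine hydrogen, or a longer chain ending in an amine. They also leave open what a propyl group or a chain ending in a carboxylic acid would do on the amide-type nitrogen, where only hydrogen and ethyl appear so far.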